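A few compounds are considered here, and "the series" means these few. Any claim that something is new, unique, unknown or untested is made for them only; others in the source may bear on it.

Measured so far:
compound 1 `CCCCCCCCCCCCCOc1cccc(N2C(N)=NC(N)=NC2(C)C)c1` — 6.52 in a functional assay on L5178Y cells (Mus musculus); on this read-out higher numbers stand for higher potency (the scale is a negative logarithm) and lower numbers for lower potency
compound 2 `CC1(C)N=C(N)N=C(N)N1c1cccc(Br)c1` — 5.9 in this assay

Within the data shown here, only two compounds have numbers, and they share a core; the two differ in what sits on the benzene ring. Of the two, compound 2 stands lowest, and compound 1 lies higher by a margin that is beyond the usual scatter of this kind of measurement. Among the measured compounds shown here, no single-point step between measured compounds is available, so nothing can yet be said about how one group trades against another here.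

Compound 3 `CC(=O)c1cccc(N2C(N)=NC(N)=NC2(C)C)c1` is the next compound, not yet measured in this assay. It differs from compound 2 in one place:

acetyl in place of bromo on an aromatic carbon

For the measured compounds named here, no measured pair shows this change, so the expectation rests on compound 2 alone, at 5.9. The expected step of no change at the digits printed from compound 2 to compound 3 (within the scatter) is none beyond the scatter, in either direction. Compound 3 is therefore estimated at 5.9, with a range from 5.2 to 6.6.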

Compound 3, logarithm of the reciprocal of the active concentration, log(1/C): 4.56
Beside the measured number, compound 3's estimate is 1.34 log units above it; the measured number lies below the stated range.
By their numbers in this assay, from the lowest: compound 3; then compound 2; then compound 1.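

Putting acetyl in place of bromo on this aromatic carbon gives a number 1.34 log units lower from compound 2 to compound 3 (beyond the scatter) in this assay, the first single-change step available for this shared core. It shows that this position, meta to a large group, does not treat all groups alike: here, one swap is enough to move the number well beyond ordinary measurement noise. Nothing measured on these compounds accounts for why the step is this large.

As far as these compounds go, with a single step, it stays open whether the drop follows from losing bromo or from gaining acetyl. How chloro, methoxy, an amine or a carboxylic acid would compare on the same carbon also remains to be seen, and any of these could help separate the two readings.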